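The compounds below may be only part of what the source reports. "The series", "measured", "known", "first", "only" and "open" are said of these compounds alone.

Measured in an ADME assay on NHDF cells (Homo sapiens) for cytotoxicity, read by MTT assay, with a stated time of 72 h; on this read-out higher numbers stand for weaker inhibition and lower numbers for stronger inhibition:
compound 1 `COc1cccc(/C=C2\CCC/C(=C\c3cccc(OC)c3OC)C2=O)c1`: 16400 nM
compound 2 `COc1ccc(/C=C2\CCC/C(=C\c3cccc(OC)c3OC)C2=O)cc1OC`: 14900 nM
compound 3 `COc1ccc(/C=C2\CCC/C(=C\c3ccc(OC)c(OC)c3)C2=O)cc1`: 30900 nM

Compound 4 `COc1ccc(/C=C2\CCC/C(=C\c3ccc(OC)c(OC)c3)C2=O)c(OC)c1` awaits measurement. Compound 2 arises from compound 1 by methoxy in place of hydrogen on an aromatic carbon, and in this assay this gave a 1.1-fold lower number from compound 1 to compound 2 (0.04 log units; within the scatter). Compound 4 arises from compound 3 by methoxy in place of hydrogen on an aromatic carbon. This is the same kind of change, but not the same: in compound 2 the entering methoxy is ortho to a methoxy group and para to a large group, whereas in compound 4 it is ortho to a large group and meta to a methoxy group. The difference between the core of compound 1 and the core of compound 3 is not broken down here. The gap between compound 3 and compound 1 lies within the scatter, that between compound 3 and compound 2 just beyond it. The expected step of a 1.1-fold lower number from compound 3 to compound 4 (0.04 log units; within the scatter) is small, because the matching step a 1.1-fold lower number from compound 1 to compound 2 (0.04 log units; within the scatter) stayed within the scatter. Compound 4 is estimated at 28000 nM, with a range from 13000 nM to 60000 nM.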

Compound 4, half-maximal inhibitory concentration: > 50000 nM
Compound 4: only a limit was reported (the forecaster's own chance of this, stated with the estimate: 10%); middle value at least 1.7-fold (0.25 log units) from the limit.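

In this assay compound 4 gives > 50000 nM, which is a limit of the assay and not a number. Methoxy in place of hydrogen, here ortho to a large group and meta to a methoxy group, gives an at least 1.6-fold higher number from compound 3 to compound 4 (0.20 log units; that floor lies within the scatter), so only a floor is known for this step. Whether the change carries from one core to another with the same result can be neither confirmed nor ruled out: the same change on two cores in this assay, a 1.1-fold lower number (0.04 log units; within the scatter) from compound 1 to compound 2 and an at least 1.6-fold higher number (0.20 log units; that floor lies within the scatter) from compound 3 to compound 4; the limit leaves it open whether they differ

The compounds shown leave open whether the core or the place of the entering methoxy decides the size of the step. They also leave open how an amine, a carboxylic acid or a longer chain would behave in that same place on either core.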